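The source may report more compounds than this note shows. Statements on the series, on what has been measured and on what is new or still open speak of the compounds shown alone.

Compounds measured so far:

Compound 1, `CC/C(=C(/c1ccc(/C=C/C(=O)O)cc1)c1cc2ccccc2[nH]1)c1ccccc1C`: 33 nM
Compound 2, `CC/C(=C(/c1ccc(/C=C/C(=O)O)cc1)c1cc2ccccc2[nH]1)c1cccc(OC(F)(F)F)c1`: 282 nM
Compound 3, `CC/C(=C(/c1ccc(/C=C/C(=O)O)cc1)c1cc2ccccc2[nH]1)c1ccc(C#N)cc1`: 278 nM

In a functional assay on MCF7 cells (Homo sapiens) for inhibition (on this read-out lower numbers stand for stronger inhibition and higher numbers for weaker inhibition), compound 1 gives the lowest of the three numbers, and its separation from both compound 2 and compound 3 lies beyond the scatter, so it is the most potent of the measured set. Compound 4, `CC/C(=C(/c1ccc(/C=C/C(=O)O)cc1)c1cc2ccccc2[nH]1)c1ccc(Cl)cc1Cl`, has not yet been measured. It differs from compound 1 in one place: 2,4-dichlorophenyl in place of 2-methylphenyl on a double-bonded chain carbon bound to a double-bonded chain carbon and a saturated chain carbon.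

Among the measured compounds shown here, two measured steps bear on this change, since each replaces the same 2-methylphenyl on the same double-bonded chain carbon. The step of an 8.5-fold higher number from compound 1 to compound 2 (0.93 log units; beyond the scatter) and the step of an 8.4-fold higher number from compound 1 to compound 3 (0.93 log units; beyond the scatter) are both modest rises of almost identical size, while the step of a 1.0-fold lower number from compound 2 to compound 3 (0.01 log units; within the scatter) shows that the two replacement groups give numbers indistinguishable from each other. On that basis a rise is expected for compound 4 as well, though the third replacement need not match the first two exactly, so the expected step of a 3.3-fold higher number from compound 1 to compound 4 (0.52 log units; beyond the scatter) is placed somewhat smaller than either measured one and with a wide range.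

Compound 4 is therefore estimated at 110 nM, expected to fall between 30 nM and 400 nM.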

Compound 4, half-maximal inhibitory concentration: 11 nM
For compound 4 the middle estimate is 10-fold (1.00 log units) above the measured one; the whole stated range lies above it.
By their numbers in this assay, from the lowest: compound 4; then compound 1; then compounds 3 and 2 (each within the scatter of the next).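

In this assay, the group on this double-bonded chain carbon can lower the number as well as raise it: 2,4-dichlorophenyl in place of 2-methylphenyl gives a drop (a 3.0-fold lower number from compound 1 to compound 4 (0.48 log units; beyond the scatter)), whereas both earlier replacements of 2-methylphenyl gave rises. Among the compounds shown here, the same position also spans a wider range than the earlier compounds showed, as 2,4-dichlorophenyl stands far from both 4-cyanophenyl (a 25-fold lower number from compound 3 to compound 4 (1.40 log units; beyond the scatter)) and 3-(trifluoromethoxy)phenyl (a 26-fold lower number from compound 2 to compound 4 (1.41 log units; beyond the scatter)), the two groups whose numbers could not be told apart. Among these four compounds, the two lowest numbers belong to the groups with a substituent at the 2 position of the phenyl, and compound 2 and compound 3, which lack one, give the two highest. Nothing available here gives a measured reason for these differences.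

The compounds shown leave open how much each chlorine contributes, since neither 2-chlorophenyl nor 4-chlorophenyl appears among them. They also do not show whether a 2-methoxyphenyl, a 2-aminophenyl or a 2,4-dimethylphenyl at this carbon would follow the same trend.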